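The source may report more compounds than this note shows. Statements on the series, on what has been measured and on what is new or still open speak of the compounds shown alone.

Compound 1 `Cc1sc2c(Nc3cccnc3)cccc2c1C` gives 24.1 ug/mL
Compound 2 `COc1ccc(Nc2cccc3c(C)c(C)sc23)cc1` gives 21.4 ug/mL
Compound 3 `COc1cccc(Nc2cccc3c(C)c(C)sc23)c1` gives 44.2 ug/mL

These values come from a functional assay on cells (Erythrocyte, Ovis aries) for inhibition, read by hemolysis; a lower number here means that less compound is needed, a higher number that more compound is needed for the effect. Compound 1 stands in the middle of the three numbers, and both compound 2 and compound 3 lie within the scatter of it.

Compound 4 `Cc1sc2c(Nc3ccccn3)cccc2c1C` is the next to be read. It keeps the core of compound 1 and carries pyridin-2-yl in place of pyridin-3-yl on a nitrogen on an aromatic ring. Among the measured compounds shown here, no measured pair isolates a change of this kind, so the data give no direct guide to its size or direction. The expectation therefore rests on the closest analogue, compound 1 at 24.1 ug/mL, and no step beyond the scatter is expected in either direction. The expected change is a 1.1-fold higher number from compound 1 to compound 4 (0.03 log units; within the scatter) and remains within the scatter. For compound 4 the estimated value is 26 ug/mL with an expected range of 11 ug/mL to 58 ug/mL in this assay.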

Compound 4, half-maximal effective concentration: 51.4 ug/mL
For compound 4 the middle estimate is 2.0-fold (0.30 log units) below the measured one, and the stated range covers the measured number.
By their numbers in this assay, from the lowest: compounds 2, 1, 3 and 4 (each within the scatter of the next, the first and the last beyond it).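

Among the compounds shown here, this is the first comparison that isolates a single change: in this assay, pyridin-2-yl in place of pyridin-3-yl on a nitrogen on an aromatic ring gives a 2.1-fold higher number from compound 1 to compound 4 (0.33 log units; beyond the scatter) and so counts as a modest step. The two groups have the same atoms and the same counts of hydrogen-bond donors and acceptors, so at this place the way those atoms are joined is enough to move the number beyond the scatter. No measurement available for these compounds accounts for the step.

Where pyridin-4-yl would fall relative to compound 1 and compound 4 remains open. Also open, as far as these compounds go, is how a carboxylic acid or an amine on the pyridine ring would shift the number at this place.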